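Swapping trifluoromethyl for methoxy on a growth inhibitor

A few compounds are considered here, and "the series" means these few. Any claim that something is new, unique, unknown or untested is made for them only; others in the source may bear on it.

Measured so far in a functional assay on UACC-62 cells (Homo sapiens) for inhibition, read by sulforhodamine B assay, with a stated time of 48 h; a lower number here means a stronger inhibitor of growth, a higher number a weaker inhibitor of growth
Compound 1 `CC1(/C=C/c2ccc(C(F)(F)F)cc2)C=CC(=O)O1` gives 15500 nM
Compound 2 `COc1ccccc1/C=C/C1(C)C=CC(=O)O1` gives 31000 nM
Compound 3 `COc1cccc(/C=C/C2(C)C=CC(=O)O2)c1` gives 55800 nM

Compound 1 (15500 nM) lies within the usual scatter of compound 2 (31000 nM), so these two cannot be told apart here. Its number is clearly lower than that of compound 3 (55800 nM), a gap beyond the scatter.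

Compound 4 `COc1ccc(/C=C/C2(C)C=CC(=O)O2)cc1` has not yet been measured. It keeps the core of compound 1 and changes a single group, with methoxy in place of trifluoromethyl on an aromatic carbon.

Within the data shown here, no measured pair differs by one change alone, so no direct step is available as a guide. Among the measured compounds shown here, the closest evidence comes from the two measured compounds that also carry methoxy, each on a different carbon from the one in compound 4. Among these, compound 2 gives 31000 nM and compound 3 gives 55800 nM, so a value in that region seems a fair expectation.

In this assay a modest rise in the number is expected, meaning weaker inhibition, with an estimated step of a 2.3-fold higher number from compound 1 to compound 4 (0.35 log units; beyond the scatter). For compound 4 the estimated value is 35000 nM, with an expected range of 15000 nM to 80000 nM.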

Compound 4, concentration for total growth inhibition: 147000 nM
Compound 4: middle estimate off by 4.2-fold (0.62 log units), on the low side, and the stated range ends below it.
By their numbers in this assay, from the lowest: compounds 1, 2 and 3 (each within the scatter of the next, the first and the last beyond it); then compound 4.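

In this assay, among these compounds, the only direct step at this position is a 9.5-fold higher number from compound 1 to compound 4 (0.98 log units; beyond the scatter) and it shows that methoxy in place of trifluoromethyl on an aromatic carbon is far from a neutral swap here, since growth inhibition clearly weakens. The site of the methoxy also appears to count, as compound 4 at 147000 nM carries a higher number than both compound 2 at 31000 nM and compound 3 at 55800 nM with methoxy on a different carbon of the ring. Nothing measured here speaks to why the number rises so far.

On these data alone, it stays open whether the rise comes from losing trifluoromethyl or from bringing in methoxy, and a plain hydrogen, a chlorine or an amine on the same carbon would help separate the two. Also open, as far as these compounds go, is how a longer chain such as ethoxy would behave on this carbon, and whether trifluoromethyl on the other ring carbons would give a lower or a higher number than compound 1.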